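Dimethylamino in Place of Sulfanyl: An Expected Partial Return

The source may report more compounds than this note shows. Statements on the series, on what has been measured and on what is new or still open speak of the compounds shown alone.

Compound 1 `Nc1nccc2c1ncn2[C@H]1C[C@H](O)[C@@H](CO)O1` gives 89% in a functional assay on EL4 cells (Mus musculus) for inhibition, tested at 100 uM; a higher number here means more inhibition at the concentration tested (going by the name of the read-out), a lower number less inhibition.
Compound 2 `OC[C@H]1O[C@@H](n2cnc3c(S)nccc32)C[C@@H]1O` gives < 5% in this assay, which is a limit of the assay and not a number.

Compound 2 thus stands at the bottom of the shown numbers, at the limit of < 5% in this assay, at which 1 of the 2 values shown sits. Compound 3 `CN(C)c1nccc2c1ncn2[C@H]1C[C@H](O)[C@@H](CO)O1` differs from it as follows: dimethylamino in place of sulfanyl on an aromatic carbon. Among the compounds with values here, the one measured step that bears on this change is a number at least 84 percentage points lower from compound 1 to compound 2 (beyond the scatter), and the change now under consideration runs the other way, back toward a nitrogen substituent at the same place. Compound 3 is therefore expected to show a partial return of inhibition, a step of a number at least 35 percentage points higher from compound 2 to compound 3 (beyond the scatter). For compound 3 the estimate is 40%, ranging from 5% to 85%.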

Compound 3, a percentage reported as inhibition, at one concentration (the size of the read-out at that concentration, not a potency): < 5%
Compound 3 gave a limit, no number (the forecaster's own chance of this, stated with the estimate: 25%); middle value at least 35 percentage points away from the limit.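

A nitrogen attached at this place on the aromatic carbon is therefore not enough on its own to keep inhibition in this assay: dimethylamino in place of amino gives a number at least 84 percentage points lower from compound 1 to compound 3 (beyond the scatter). Of the compounds shown, only compound 1, with amino, shows a readable inhibition. Compound 2 and compound 3 both stand at a limit of the assay, not a number, so the step between them cannot be read: the limit of < 5% in this assay, at which 2 of the 3 values shown sit.

The compounds shown leave open whether methylamino or hydroxyl at this place would keep any of the inhibition seen with amino. They also leave open how far compound 2 and compound 3 really differ.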